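Aryl sulfonamide variation in a thio-heterocyclic antiproliferative series

A few compounds are considered here, and "the series" means these few. Any claim that something is new, unique, unknown or untested is made for them only; others in the source may bear on it.

Measured so far:
Compound 1, `O=S(=O)(NC1=NCCN1C(=S)SN1CCn2c1nsc2=S)c1ccc(C(F)(F)F)cc1`: in a functional assay on KYSE-510 cells (Homo sapiens) for antiproliferative activity, read by crystal violet staining, with a stated time of 96 h (a lower number here means a stronger inhibitor of growth, a higher number a weaker inhibitor of growth), compound 1 gives >= 20000 nM, a limit of the assay.
Compound 2, `COc1ccc(S(=O)(=O)NC2=NCCN2C(=S)SN2CCn3c2nsc3=S)cc1`: in this assay compound 2 gives >= 20000 nM, again a limit rather than a number.

Compound 2 therefore stands nowhere definite on the numbers shown: its value is a limit, and the one further value in the set is a limit too. Going by the values given here, the single measured step, a step that the two limits leave unreadable from compound 1 to compound 2, cannot be read because both of its ends sit at the limit of >= 20000 nM in this assay, at which 2 of the 2 values shown sit. Among the compounds with values here, nothing so far says whether the aryl group on the sulfonyl sulfur moves growth inhibition at all.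

Compound 3, `COc1ccc(OC)c(S(=O)(=O)NC2=NCCN2C(=S)SN2CCn3c2nsc3=S)c1`, continues the same change of aryl group: 2,5-dimethoxyphenyl in place of 4-methoxyphenyl on a sulfonyl sulfur. Within the data shown here, the only step that bears on it, from compound 1 to compound 2, has no readable size, so no step beyond the scatter can be expected in this assay in either direction, and the most likely outcome is a further limit. The expected step that the limit leaves unreadable from compound 2 to compound 3 is accordingly one of no readable movement. Compound 3 is estimated at 25000 nM, with a range from 8000 nM to 80000 nM.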

Compound 3, concentration for 50% growth inhibition: >= 20000 nM
Compound 3: only a limit was reported (the forecaster's own chance of this, stated with the estimate: 85%); the middle value lies beyond the limit too.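

In this assay compound 3 gives >= 20000 nM, again a limit of the assay. Going by these compounds alone, no step among compound 1, compound 2 and compound 3 can be read, because all three values sit at the same limit: the limit of >= 20000 nM in this assay, at which 3 of the 3 values shown sit. The compounds shown leave open whether changing the aryl group on the sulfonyl sulfur moves growth inhibition at all.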